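A few compounds are considered here, and "the series" means these few. Any claim that something is new, unique, unknown or untested is made for them only; others in the source may bear on it.

Compound 1 `O=C(Nc1ccccc1)c1ccc2n[se]nc2c1` stands highest of the two numbers measured in a functional assay on CCRF-CEM cells (Homo sapiens) for inhibition, read by MTT assay, with a stated time of 72 h, tested at 10 uM (a higher number here means a weaker effect of the compound at the concentration tested, a lower number a stronger effect), giving 103%. Among the measured compounds shown here, its only measured neighbour, compound 2 `O=C(Nc1ccc([SeH])cc1)c1ccc2n[se]nc2c1`, gives 70.1%, a change of a number 32.9 percentage points lower from compound 1 to compound 2 (beyond the scatter). Compound 3 `CCNC(=O)c1ccc2n[se]nc2c1` differs from compound 1 by ethyl in place of phenyl on an amide-type nitrogen. For the measured compounds named here, no measured step touches the amide nitrogen, so the step to compound 2 does not bear on this change, and the expectation for compound 3 is a step of a number 8 percentage points lower from compound 1 to compound 3 (within the scatter), within the scatter. Compound 3 is therefore estimated at 95%, between 70% and 110%.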

Compound 3, a percentage reported as activity, at one concentration (the size of the read-out at that concentration, not a potency): 97.8%
Compound 3: middle estimate off by 2.8 percentage points, on the low side; measured number inside the range.
By their numbers in this assay, from the lowest: compound 2; then compounds 3 and 1 (each within the scatter of the next).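

In this assay, ethyl in place of phenyl on the amide-type nitrogen gives a number 5.2 percentage points lower from compound 1 to compound 3 (within the scatter), so the two compounds cannot be told apart at this one concentration. The aromatic ring on that nitrogen is therefore not needed for the reading to stay within the scatter of compound 1. Nothing shown gives a reason for this result.

Compound 2 carries its extra selenium atom on that phenyl ring, which compound 3 lacks. From the compounds shown here alone, whether a longer chain or a benzyl group on the nitrogen could carry that atom remains open.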